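A few compounds are considered here, and "the series" means these few. Any claim that something is new, unique, unknown or untested is made for them only; others in the source may bear on it.

Working notes on the series.

Three compounds in the set have numbers in a functional assay on MGC-803 cells (Homo sapiens) for inhibition, read by MTT assay, with a stated time of 72 h; on this read-out lower numbers stand for stronger inhibition and higher numbers for weaker inhibition. Compound 1 `O=C(CSc1nc(Nc2ccccc2)c2ccccc2n1)Nc1ccccc1Cl` gives 24800 nM; compound 2 `O=C(CSc1nc(Nc2ccccc2)c2ccccc2n1)Nc1ccc(Br)cc1` gives 19300 nM; compound 3 `C=CC(=O)Nc1cccc(NC(=O)CSc2nc(Nc3ccccc3F)c3ccccc3n2)c1` gives 26100 nM. Going by the values given here, the one step the set supports, a 1.3-fold lower number from compound 1 to compound 2 (0.11 log units; within the scatter), lies within the scatter, and compound 3 sits within the scatter of both compound 1 and compound 2, so the three numbers cannot be told apart.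

Compound 4 `C=CC(=O)Nc1cccc(NC(=O)CSc2nc(Nc3cccc(F)c3)c3ccccc3n2)c1` is the next member. It differs from compound 3 only in 3-fluorophenyl in place of 2-fluorophenyl on a nitrogen on an aromatic ring. Among the compounds with values here, no measured pair in the set moves a fluorine on this ring, so nothing bears directly on the change; the only measured step, from compound 1 to compound 2, concerns the aryl on the amide-type nitrogen, sits at a different place and was itself within the scatter. Everything in the set points to a flat surface: every variation tried so far has stayed within the scatter.

The expectation for this assay is therefore no step beyond the scatter, with the estimated step of a 1.0-fold lower number from compound 3 to compound 4 (0.00 log units; within the scatter). Compound 4 is estimated at 26000 nM, with a range from 10000 nM to 65000 nM, because compound 3 gives 26100 nM and no measured step gives reason to move away from it.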

Compound 4, half-maximal inhibitory concentration: 6250 nM
Compound 4: middle estimate off by 4.2-fold (0.62 log units), on the high side; the whole stated range lies above it.
By their numbers in this assay, from the lowest: compound 4; then compounds 2, 1 and 3 (each within the scatter of the next).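

In this assay, going by these compounds alone, a 4.2-fold lower number from compound 3 to compound 4 (0.62 log units; beyond the scatter) is the first step to lie beyond the scatter, so the surface is not flat at this place. Within the data shown here, the two compounds have the same atoms and differ only in 3-fluorophenyl in place of 2-fluorophenyl on the nitrogen, which shows that the read-out responds to where the fluorine sits on this ring, whereas the only earlier step, a 1.3-fold lower number from compound 1 to compound 2 (0.11 log units; within the scatter), concerned the aryl on the amide-type nitrogen and stayed within the scatter. Nothing in hand accounts for the difference between the two fluorine placements.

With only these two placements shown, it remains open whether the trend extends to 4-fluorophenyl or whether a larger group at the same ring place, such as 3-chlorophenyl or 3-methoxyphenyl, would hold or extend the modest step. From the compounds shown here alone, it is also open whether the same change would give a step of similar size with a different aryl on the amide-type nitrogen, such as the 4-bromophenyl of compound 2, in place of the acrylamide-bearing aryl.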